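Half-life notes: a new ring on the chain carbon

This account rests on a few compounds, and the source may have more. Where it says the series, first, only, none or still open, it means among the compounds named here.

Measured in an ADME assay on microsomes from liver (Homo sapiens) for metabolic stability; a higher number here means that the compound lasts longer, a lower number that the compound disappears faster:
compound 1 `CC(C)C(Cc1ncc[nH]1)c1ccc(-c2ccc3cccc(F)c3c2)[nH]c1=O`: 0.106 h
compound 2 `CC(C)C(c1noc(=O)[nH]1)c1ccc(-c2ccc3cccc(F)c3c2)[nH]c1=O`: > 3 h

Compound 2 stands at > 3 h, which is a limit of the assay and not a number. Its place in the series rests on (the limit of > 3 h in this assay, at which 1 of the 2 values shown sits).

The next structure is compound 3 `CC(C)C(c1ccc(-c2ccc3cccc(F)c3c2)[nH]c1=O)N1CCNC1=O`, and the change is a group of 6 heavy atoms (3 carbon, 2 nitrogen, 1 oxygen; one five-membered non-aromatic ring with 2 hetero atoms) in place of a group of 6 heavy atoms (2 carbon, 2 nitrogen, 2 oxygen; one five-membered aromatic ring with 3 hetero atoms), on a saturated chain carbon bound to an aromatic carbon and a saturated chain carbon. The 2-oxoimidazolidin-1-yl group, a five-membered non-aromatic ring, enters on a saturated chain carbon bound to an aromatic carbon and a saturated chain carbon.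

Going by the values given here, the one measured step that bears on this is an at least 28-fold higher number from compound 1 to compound 2 (1.45 log units; beyond the scatter), large and beyond the scatter, made at the same carbon. It shows that the group at this carbon can move the half-life a long way, but it gives no size for a non-aromatic ring. The expected step is an at least 2.0-fold lower number from compound 2 to compound 3 (0.30 log units; that floor lies within the scatter), downward in this assay and much smaller than the measured one, with a reading at the limit still possible. For compound 3 the estimate is 1.5 h, with an expected range of 0.4 h to 6 h.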

Compound 3, half-life: 1.03 h
Beside the measured number, compound 3's estimate is 1.5-fold (0.16 log units) above it, and the stated range covers the measured number.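

Going by these compounds alone, the 2-oxoimidazolidin-1-yl group gives the first reading for a non-aromatic ring on this saturated chain carbon in this assay, and it keeps much of the gain seen at this position, with a 9.7-fold higher number from compound 1 to compound 3 (0.99 log units; beyond the scatter). Against the five-membered aromatic ring with three hetero atoms, the same group gives an at least 2.9-fold lower number from compound 2 to compound 3 (0.46 log units; beyond the scatter), so two rings of equal heavy-atom count are separated beyond the scatter and ring size alone does not set the half-life among these compounds. Compound 2 gives > 3 h, which is a limit of the assay and not a number, so the step from it has only a floor and its true size stays unknown: the limit of > 3 h in this assay, at which 1 of the 3 values shown sits.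

The compounds shown leave open what an open-chain amide, a carboxylic acid or an amine would give on this carbon, and so whether a ring is needed there at all. Also open, on these data alone, is how much of the rise from compound 1 belongs to the change of ring and how much to the loss of the methyl link in (1H-imidazol-2-yl)methyl, as these two changes come together in every step from compound 1.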